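The source may report more compounds than this note shows. Statements on the series, on what has been measured and on what is new or still open speak of the compounds shown alone.

In an ADME assay on Caecum (Rattus norvegicus, strain Sprague-Dawley) for metabolic stability, read by LC-MS, tested at 10 uM (on this read-out lower numbers stand for a shorter-lived compound and higher numbers for a longer-lived compound), compound 1 `C[C@@H](N[C@H]1CCN(c2ccc(S(=O)(=O)NCC(=O)O)cc2)C1)c1cccc2ccccc12` gives > 12 h, which is a limit of the assay and not a number. Compound 2 `C[C@@H](N[C@H]1CCN(c2ccc(C(=O)NCCS(=O)(=O)O)cc2)C1)c1cccc2ccccc12` gives 0.8 h and compound 3 `C[C@@H](N[C@H]1CCN(c2ccc(C(=O)N[C@H](CCCCN)C(=O)O)cc2)C1)c1cccc2ccccc12` gives 4.3 h, so compound 3 holds the higher of the two actual numbers. Compound 4 `C[C@@H](N[C@H]1CCN(c2ccc(C(=O)N[C@H](CC(=O)O)C(=O)O)cc2)C1)c1cccc2ccccc12` has not yet been measured. It departs from compound 3 in one place: carboxy in place of 3-aminopropyl on a saturated chain carbon, two bonds along the chain from an amide-type nitrogen and a carbonyl carbon. The same difference, cut one bond further out, reads 5-amino-1-carboxypentyl to 1,2-dicarboxyethyl. The closest measured precedent is a change on the same amide-type nitrogen, a 5.4-fold higher number from compound 2 to compound 3 (0.73 log units; beyond the scatter), and it was modest. The other two steps, an at least 15-fold lower number from compound 1 to compound 2 (1.17 log units; beyond the scatter) and an at least 2.7-fold lower number from compound 1 to compound 3 (0.44 log units; beyond the scatter), also replace the (carboxymethyl)sulfamoyl group and so bear on this change less directly. Among the compounds with values here, no measured step isolates the loss of 3-aminopropyl, which leaves the direction open, so no step beyond the scatter is the expectation in this assay. The expected change is a 1.4-fold lower number from compound 3 to compound 4 (0.16 log units; within the scatter). Compound 4 is estimated at 3 h, with an expected range of 0.9 h to 10 h.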

Compound 4, half-life: 9.1 h
For compound 4 the middle estimate is 3.0-fold (0.48 log units) below the measured one; the range from low to high includes it.
By their numbers in this assay, from the lowest: compound 2; then compound 3; then compound 4. At a limit, above all of these: compound 1.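

In this assay, within the data shown here, carboxy in place of 3-aminopropyl on a saturated chain carbon, two bonds along the chain from an amide-type nitrogen and a carbonyl carbon, gives a 2.1-fold higher number from compound 3 to compound 4 (0.33 log units; beyond the scatter), the first step to isolate this position and the first to show a direction for the change. With 1,2-dicarboxyethyl in place of 2-sulfoethyl on the amide-type nitrogen, the result is an 11-fold higher number from compound 2 to compound 4 (1.06 log units; beyond the scatter), so a long-lived compound in this series does not need the 3-aminopropyl group. Compound 1 gives > 12 h, which is a limit and not a number: the limit of > 12 h in this assay, at which 1 of the 4 values shown sits.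
Measured against that limit, the data give an at least 1.3-fold lower number from compound 1 to compound 4 (0.12 log units; that floor lies within the scatter) and no more.

The compounds shown do not separate the loss of 3-aminopropyl from the gain of carboxy, as both occur in the same step. A methyl group at this carbon would separate the two, and a carboxyethyl chain would test whether the length of the acid-bearing chain matters.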